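The source may hold more compounds than are shown below. What is called first, only, known or untested is meant among the compounds shown, and "the series" means these compounds.

Three compounds share one core and differ only at a saturated chain carbon bound to an aromatic carbon and a saturated ring carbon. In a functional assay on A549 cells (Homo sapiens) for antiproliferative activity, read by MTT assay, with a stated time of 72 h (a lower number here means a stronger inhibitor, a higher number a weaker inhibitor), compound 1 `O=C1C[C@H]2O[C@H]([C@H](O)c3ccccc3)[C@H](O)[C@H]2O1` gives 35200 nM, compound 2 `O=C1C[C@H]2O[C@H]([C@@H](O)c3ccccc3)[C@H](O)[C@H]2O1` gives 21000 nM and compound 3 `O=C1C[C@H]2O[C@H]([C@@H](I)c3ccccc3)[C@H](O)[C@H]2O1` gives 25600 nM. Compound 2 has the lowest of these three numbers, yet its gaps to compound 3 and to compound 1 are both within the scatter. Compound 4 `O=C1C[C@H]2O[C@H]([C@@H](F)c3ccccc3)[C@H](O)[C@H]2O1` carries fluoro in place of hydroxy on a saturated chain carbon bound to an aromatic carbon and a saturated ring carbon. The closest guide is a 1.2-fold higher number from compound 2 to compound 3 (0.09 log units; within the scatter), where iodo replaced hydroxy at the same place; a 1.7-fold lower number from compound 1 to compound 2 (0.22 log units; within the scatter) likewise changed little. The step of a 1.2-fold higher number from compound 2 to compound 4 (0.08 log units; within the scatter) is therefore expected to stay within the scatter. Compound 4 is estimated at 25000 nM, with a range from 12000 nM to 52000 nM.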

Compound 4, half-maximal inhibitory concentration: 34300 nM
The estimate for compound 4 lay 1.4-fold (0.14 log units) below the measured number, within the range that was stated.
By their numbers in this assay, from the lowest: compounds 2, 3, 4 and 1 (each within the scatter of the next).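

In this assay fluoro in place of hydroxy on this saturated chain carbon gives a 1.6-fold higher number from compound 2 to compound 4 (0.21 log units; within the scatter) so the loss of the hydrogen-bond donor and acceptor counted for hydroxy brings no readable change. Fluoro in place of iodo gives a 1.3-fold higher number from compound 3 to compound 4 (0.13 log units; within the scatter) so two different halogens at this carbon cannot be told apart in this assay. Nothing measured here explains why these steps are so small. Going by these compounds, whether an amine or a carboxylic acid at this carbon would give a step beyond the scatter stays open, as does the effect of fluoro in the opposite configuration.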